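This account rests on a few compounds, and the source may have more. Where it says the series, first, only, none or still open, it means among the compounds named here.

Measured compounds in a functional assay on Jurkat cells (Homo sapiens) for inhibition; on this read-out lower numbers stand for stronger inhibition and higher numbers for weaker inhibition:
compound 1, `CC(C)[C@H](NC(=O)COc1cccc2ccccc12)C(=O)N[C@@H](CC(=O)O)C(=O)CSc1nnc(-c2ccccc2)o1`, with 150000 nM
compound 2, `Cc1nnc(SCC(=O)[C@H](CC(=O)O)NC(=O)[C@@H](NC(=O)COc2cccc3ccccc23)C(C)C)s1`, with 190000 nM
compound 3, `CC(C)[C@H](NC(=O)COc1cccc2ccccc12)C(=O)N[C@@H](CC(=O)O)C(=O)COc1cc(C(F)(F)F)ncn1`, for which this assay gives only a limit, > 200000 nM

Compound 2 carries the higher of the two actual numbers, though a 1.3-fold higher number from compound 1 to compound 2 (0.10 log units; within the scatter) shows that this ranking lies within the scatter. Compound 4, `CC(C)[C@H](NC(=O)COc1cccc2ccccc12)C(=O)N[C@@H](CC(=O)O)C(=O)COc1nncc(Cl)c1Cl`, differs from compound 2 by (4,5-dichloropyridazin-3-yl)oxy in place of (5-methyl-1,3,4-thiadiazol-2-yl)sulfanyl on a saturated chain carbon bound to a carbonyl carbon. The measured step that comes closest is an at least 1.0-fold higher number from compound 2 to compound 3 (0.02 log units; that floor lies within the scatter), where a six-membered aromatic ring joined through oxygen also took the place of a sulfanyl-linked five-membered ring at the same carbon; an at least 1.3-fold higher number from compound 1 to compound 3 (0.12 log units; that floor lies within the scatter) tells the same story from the other starting point. Both end at the limit of > 200000 nM in this assay, at which 1 of the 3 values shown sits, so the data offer no sign that such a swap moves this assay beyond its scatter, and a fair chance remains that compound 4 likewise returns only a limit. Compound 4 is therefore expected to give 200000 nM, within 100000 nM to 400000 nM. The estimate implies an expected step of a 1.1-fold higher number from compound 2 to compound 4 (0.02 log units; within the scatter).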

Compound 4, half-maximal inhibitory concentration: > 200000 nM
Compound 4: a limit, no number; the forecaster's own chance of this, stated with the estimate: 50%; the middle value sits exactly at the limit.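

Compound 4 in this assay gives only a limit, > 200000 nM, so a second six-membered aromatic ring joined through oxygen at this saturated chain carbon bound to a carbonyl carbon ends at that limit: the limit of > 200000 nM in this assay, at which 2 of the 4 values shown sit.

The floors in an at least 1.0-fold higher number from compound 2 to compound 4 (0.02 log units; that floor lies within the scatter) and an at least 1.3-fold higher number from compound 1 to compound 4 (0.12 log units; that floor lies within the scatter) lie within the scatter, so the entry of (4,5-dichloropyridazin-3-yl)oxy shows no change beyond the scatter, though neither floor rules one out. The step between compound 3 and compound 4 cannot be read.

From the compounds shown here alone, how far compound 3 and compound 4 lie past the limit stays open. Also open, going by these compounds, is whether a different group on this carbon, such as 2,6-difluorophenoxy or an aliphatic amine, would give a step beyond the scatter.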